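Swapping Methyl for Cyano on the Pyrazole of Compound 3

The source may hold more compounds than are shown below. What is called first, only, known or untested is meant among the compounds shown, and "the series" means these compounds.

Of the compounds shown here, three have been measured in an assay on membranes from brain for binding affinity to Fatty-acid amide hydrolase 1 (Mus musculus), read by fluorescence, with stated times of 1 h and 30 min; on this read-out higher numbers stand for weaker inhibition and lower numbers for stronger inhibition. Compound 1 `Cc1cnn(C(=O)N2CCCCC2)c1` gives 2200 nM. Compound 2 `O=C(N1CCCN(Cc2ccc(OCc3ccccc3)cc2)CC1)n1cccn1` gives 450 nM. Compound 3 `Cc1cnn(C(=O)N(C)CCN(C)Cc2cccc(OCc3ccccc3)c2)c1` gives 9000 nM, the highest of the three numbers, so compound 3 is the weakest inhibitor of the three; its nearest neighbour on the scale is compound 1, and its furthest is compound 2, and both gaps lie beyond the usual scatter of this assay.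

Compound 4 `CN(CCN(C)C(=O)n1cc(C#N)cn1)Cc1cccc(OCc2ccccc2)c1` differs from compound 3 in one place: cyano in place of methyl on an aromatic carbon. Among the compounds with values here, nothing else in the molecule changes, and no measured pair here shows the same change, so its effect has to be guessed. Since the 4-methyl-1H-pyrazol-1-yl of compound 3 is replaced by 4-cyano-1H-pyrazol-1-yl, the expectation is a step of moderate size toward a lower number, that is toward stronger inhibition, and the step from compound 3 to compound 4 is estimated at a 6.0-fold lower number from compound 3 to compound 4 (0.78 log units; beyond the scatter). In this assay compound 4 is expected to give about 1500 nM, with a likely range from 300 nM to 6000 nM.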

Compound 4, half-maximal inhibitory concentration: 190 nM
Compound 4: middle estimate off by 7.9-fold (0.90 log units), on the high side; the whole stated range lies above it.
By their numbers in this assay, from the lowest: compound 4; then compound 2; then compound 1; then compound 3.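

Within the data shown here, until now, no two compounds differed in just one place, so nothing could show how much this aromatic carbon, two ring bonds from the ring nitrogen, matters on its own. In this assay, cyano in place of methyl there gives a 47-fold lower number from compound 3 to compound 4 (1.68 log units; beyond the scatter), a large step toward stronger inhibition, which shows that a single group at this position can strongly affect the read-out, with the rest of the molecule unchanged. Nothing given here says why this change has such an effect.

The compounds shown leave open how other groups would behave on the same carbon, such as a chlorine atom, a trifluoromethyl group, a carboxylic acid or a primary amide, so one step cannot yet reveal a trend at this position. They also leave open whether replacing 4-methyl-1H-pyrazol-1-yl with 4-cyano-1H-pyrazol-1-yl would give a step of similar size in compound 1, which carries the same methyl-bearing ring on a different remaining structure.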